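Solubility notes: from compound 2 to compound 3

The source may report more compounds than this note shows. Statements on the series, on what has been measured and on what is new or still open speak of the compounds shown alone.

Going by the values given here, compound 2 `O=C1CC2(CC2)CN1c1cnc(NCc2c(F)ccc3c2CCO3)n2cnnc12` is the only compound here with a numeric reading in a physicochemical assay for solubility, read by LC-MS, in phosphate buffer, with a stated time of 24 h, at pH 7.4 (a lower number here means a less soluble compound, a higher number a more soluble compound), where compound 2 gives 130000 nM. Compound 1 `Cc1nc(CN(C)C)ccc1-c1cnc(NCc2c(F)ccc3c2CCO3)c2cn[nH]c(=O)c12` gives only a limit of the assay in this assay, namely > 1000000 nM, which is the limit of > 1000000 nM in this assay, at which 1 of the 2 values shown sits. Compound 3 `CN(C(=O)c1ccccc1)c1cnc(NCc2c(F)ccc3c2CCO3)n2cnnc12` has not yet been measured in this assay. Compound 3 differs from compound 2 by a group of 10 heavy atoms (8 carbon, 1 nitrogen, 1 oxygen; one six-membered aromatic ring of carbon only) in place of a group of 8 heavy atoms (6 carbon, 1 nitrogen, 1 oxygen; one three-membered non-aromatic ring of carbon only, one five-membered non-aromatic ring with 1 hetero atom), on an aromatic carbon. Among the compounds with values here, no measured step between two compounds is available, so the size of this step is open; a modest fall, close to the scatter, is expected. Compound 3 is estimated at 70000 nM, within 20000 nM to 250000 nM. The expected step is a 1.9-fold lower number from compound 2 to compound 3 (0.27 log units; within the scatter).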

Compound 3, solubility: 280000 nM
The estimate for compound 3 lay 4.0-fold (0.60 log units) below the measured number; the whole stated range lies below it.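

At this aromatic carbon, para to a large group, the entry of benzoyl(methyl)amino gives a 2.2-fold higher number from compound 2 to compound 3 (0.33 log units; beyond the scatter) in this assay. Going by these compounds alone, this is the first readable step at this position, and the groups that leave and enter carry the same counts of hydrogen-bond donors and acceptors and no net charge. Nothing measured here gives a cause for this step.

A single step leaves open how an amine, a carboxylic acid or a longer chain at this carbon would read in this assay. On these data alone, whether the step carries over to the core of compound 1 also stays open.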